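This account rests on a few compounds, and the source may have more. Where it says the series, first, only, none or still open, it means among the compounds named here.

Compound 1 `CCCOc1cc([C@](O)(CCN(C)C)[C@@H](c2cc3cc(Br)ccc3nc2OC)c2ccnc(OC)c2OC)cc(OC)n1` and compound 2 `COc1cc([C@](O)(CCN(C)C)[C@@H](c2cc3cc(Br)ccc3nc2OC)c2ccnc(OC)c2OC)cc(OC2CCC2)n1` share one core and differ only on an oxygen on an aromatic ring. In an ADME assay on microsomes from liver (Homo sapiens) for metabolic stability (on this read-out higher numbers stand for fast clearance and lower numbers for slow clearance), compound 1 gives 8.2 uL/min, while compound 2 gives 2.5 uL/min, a step of a 3.3-fold lower number from compound 1 to compound 2 (0.52 log units; beyond the scatter). Among the compounds with values here, compound 2 therefore stands lowest of the two numbers measured so far. Compound 3 `COc1cc([C@](O)(CCN(C)C)[C@@H](c2cc3cc(Br)ccc3nc2OC)c2ccnc(OC)c2OC)cc(OC(F)F)n1` carries the change (difluoromethyl in place of cyclobutyl on an oxygen on an aromatic ring). Within the data shown here, only the step from compound 1 to compound 2 bears on this change, and it does not involve difluoromethyl, so the direction remains open. A step of a 1.4-fold higher number from compound 2 to compound 3 (0.15 log units; within the scatter) is expected, and compound 3 is estimated at 3.5 uL/min, within 1.5 uL/min to 8 uL/min.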

Compound 3, intrinsic clearance in a liver preparation (reported as CLH), per the amount of preparation that the assay uses: 2.1 uL/min
Compound 3: middle estimate off by 1.7-fold (0.22 log units), on the high side; the measured number falls inside the stated range.
By their numbers in this assay, from the lowest: compounds 3 and 2 (each within the scatter of the next); then compound 1.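

In this assay the swap gives a 1.2-fold lower number from compound 2 to compound 3 (0.08 log units; within the scatter) and so does not separate difluoromethyl from cyclobutyl on this oxygen. Set against propyl, difluoromethyl gives a 3.9-fold lower number from compound 1 to compound 3 (0.59 log units; beyond the scatter) and thus joins cyclobutyl on the low side, showing that a group with no ring can also sit there. Nothing measured here explains these numbers.

Still open, from the compounds shown here alone, is how trifluoromethyl, an amine or a longer chain would read on this oxygen. Going by these compounds, whether the same swaps would give similar steps on a different core also remains unknown.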